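Chlorophenyl positional swap on hydroxyphenyl-thienyl pyridines

The source may report more compounds than this note shows. Statements on the series, on what has been measured and on what is new or still open speak of the compounds shown alone.

Compound 1 `Oc1cccc(-c2cc(-c3ccc(Cl)cc3)nc(-c3cccs3)c2)c1` and compound 3 `Oc1cccc(-c2cc(-c3cccs3)nc(-c3ccccc3Cl)c2)c1` share one core. In an assay on isolated protein for inhibition of DNA topoisomerase 1 (Homo sapiens), with a stated time of 30 min, tested at 100 uM (a lower number here means a weaker effect, a higher number a stronger effect of the compound at the concentration tested), compound 1 gives 15.1% and compound 3 gives 2.7%. The change between them, (2-chlorophenyl in place of 4-chlorophenyl on an aromatic carbon), makes a step of a number 12.4 percentage points lower from compound 1 to compound 3 (beyond the scatter). Compound 2 `Oc1ccc(-c2cc(-c3ccc(Cl)cc3)nc(-c3ccsc3)c2)cc1` sits on a second core, and its difference from compound 1 is not broken down here. In this assay compound 2 gives 47.7%, the highest of the three measured values. Compound 4 `Oc1ccc(-c2cc(-c3ccsc3)nc(-c3ccccc3Cl)c2)cc1` differs from compound 2 by 2-chlorophenyl in place of 4-chlorophenyl on an aromatic carbon. Going by the values given here, this is the same kind of change as the one from compound 1 to compound 3, though here the place is meta to a 4-hydroxyphenyl group and meta to a thiophen-3-yl group, rather than meta to a 3-hydroxyphenyl group and meta to a thiophen-2-yl group. Compound 4 is therefore expected to give 33%, between 15% and 50%, an estimated step of a number 14.7 percentage points lower from compound 2 to compound 4 (beyond the scatter), resting on the drop seen as a number 12.4 percentage points lower from compound 1 to compound 3 (beyond the scatter) applied from a higher starting value.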

Compound 4, a percentage reported as inhibition, at one concentration (the size of the read-out at that concentration, not a potency): 4.1%
Compound 4: the middle estimate sits 28.9 percentage points above what was measured; the whole stated range lies above it.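

In this assay, 2-chlorophenyl in place of 4-chlorophenyl gives a number 43.6 percentage points lower from compound 2 to compound 4 (beyond the scatter). The direction of the change carries from one core to the other, but its size does not: the same change on two cores in this assay, a number 12.4 percentage points lower (beyond the scatter) from compound 1 to compound 3 and a number 43.6 percentage points lower (beyond the scatter) from compound 2 to compound 4, 31.2 percentage points apart, beyond the scatter of two such steps. Going by these compounds alone, with only two pairs, this does not show whether the hydroxyphenyl group, the thiophene group or both set the size of the step, so a step measured on one core is a poor estimate of its size on another.

Still open, from the compounds shown here alone, is the step on a core pairing 3-hydroxyphenyl with thiophen-3-yl, or 4-hydroxyphenyl with thiophen-2-yl. Also open, going by these compounds, is how a 3-chlorophenyl group, or a phenyl ring carrying an amine or a carboxylic acid in place of the chlorine, would read at this place.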